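The compounds below may be only part of what the source reports. "The series", "measured", "known", "first", "only" and "open" are said of these compounds alone.

Measured so far in a functional assay on cells (Neutrophil, Homo sapiens) for inhibition, with a stated time of 10 min; a lower number here means a stronger inhibitor, a higher number a weaker inhibitor:

compound 1 `CCOC(=O)c1cnn(CC(C)O)c1NC(=O)NCc1ccccc1`: 15 nM
compound 2 `CCOC(=O)c1cnn(C)c1NC(=O)NCc1ccccc1`: 18 nM
compound 3 `CCOC(=O)c1cnn(C)c1NC(=O)NC(C)C`: 77 nM

Within this set, compound 3 stands highest; its nearest neighbour is compound 2, with a 4.3-fold higher number from compound 2 to compound 3 (0.63 log units; beyond the scatter). That core change is isopropyl in place of benzyl on an amide-type nitrogen.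

Compound 4 `CCOC(=O)c1cnn(CC(C)O)c1NC(=O)NC(C)C` is not yet measured. Compound 3 to compound 4 is 1-hydroxyethyl in place of hydrogen on a saturated chain carbon bound to an aromatic nitrogen. The same change was made from compound 2 to compound 1, where it gave a 1.2-fold lower number from compound 2 to compound 1 (0.08 log units; within the scatter). The place of the change is the same in both pairs, so it is treated as the same change on a different core.

The step from compound 3 to compound 4 in this assay is expected to be a 1.2-fold lower number from compound 3 to compound 4 (0.07 log units; within the scatter), resting on compound 2 to compound 1 with a 1.2-fold lower number from compound 2 to compound 1 (0.08 log units; within the scatter). Compound 4 is therefore estimated at 65 nM, with a range from 30 nM to 150 nM.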

Compound 4, half-maximal inhibitory concentration: 90 nM
The estimate for compound 4 lay 1.4-fold (0.14 log units) below the measured number, and the stated range covers the measured number.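

In this assay, 1-hydroxyethyl in place of hydrogen gives a 1.2-fold higher number from compound 3 to compound 4 (0.07 log units; within the scatter), and this step agrees with the one on the earlier core: the same change on two cores in this assay, a 1.2-fold lower number (0.08 log units; within the scatter) from compound 2 to compound 1 and a 1.2-fold higher number (0.07 log units; within the scatter) from compound 3 to compound 4, 1.4-fold (0.15 log units) apart, within the scatter of two such steps. Isopropyl in place of benzyl gives a 6.0-fold higher number from compound 1 to compound 4 (0.78 log units; beyond the scatter), which also carries over: the same change on two cores in this assay, a 4.3-fold higher number (0.63 log units; beyond the scatter) from compound 2 to compound 3 and a 6.0-fold higher number (0.78 log units; beyond the scatter) from compound 1 to compound 4, 1.4-fold (0.15 log units) apart, within the scatter of two such steps. Each change therefore transfers between the two cores shown, but each rests on only two pairs. The 1-hydroxyethyl steps stay within the scatter. They show no measurable effect being carried over rather than a real shift being preserved.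

Going by these compounds, it remains open whether an amine or a carboxylic acid on the chain in place of 1-hydroxyethyl would move the number. On these data alone, it also remains open whether the isopropyl-to-benzyl difference extends to a cyclohexyl or a longer chain on the same nitrogen.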